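Swapping Bromine for Chlorine on a Second Core

This account rests on a few compounds, and the source may have more. Where it says the series, first, only, none or still open, it means among the compounds named here.

Compound 1 `COc1ccc(C2=NN(C3=NC(=O)/C(=C4\C(=O)Nc5ccc(Br)cc54)S3)C(c3ccc(Cl)cc3)C2)cc1` and compound 2 `COc1ccc(C2=NN(C3=NC(=O)/C(=C4\C(=O)Nc5ccc(Cl)cc54)S3)C(c3ccc(Cl)cc3)C2)cc1` share one core and differ at a single aromatic carbon. In a functional assay on cells (Leukemia cell, Homo sapiens) for cytotoxicity, read by sulforhodamine B assay, with a stated time of 48 h (on this read-out higher numbers stand for weaker inhibition of growth and lower numbers for stronger inhibition of growth), compound 1 gives 14000 nM, while compound 2 gives 890 nM, a change of a 16-fold lower number from compound 1 to compound 2 (1.20 log units; beyond the scatter); the structural change is chloro in place of bromo on an aromatic carbon. Compound 3 `COc1ccc(-c2cc(-c3ccc(Cl)cc3)n(C3C(=O)Nc4ccc(Br)cc43)n2)cc1` is built on a different core; how its core differs from that of compound 1 is not broken down here. In this assay compound 3 gives 67000 nM, the highest of the three numbers. Compound 4 `COc1ccc(-c2cc(-c3ccc(Cl)cc3)n(C3C(=O)Nc4ccc(Cl)cc43)n2)cc1` has not yet been measured; it arises from compound 3 by chloro in place of bromo on an aromatic carbon, the same change that turned compound 1 into compound 2. Among the measured compounds shown here, because that step was a 16-fold lower number from compound 1 to compound 2 (1.20 log units; beyond the scatter), a drop is expected here too, though a smaller one: only one measured example of this change exists, and the two cores differ. Compound 4 is expected to show a 4.5-fold lower number from compound 3 to compound 4 (0.65 log units; beyond the scatter). The estimate for compound 4 is 15000 nM, expected to fall between 4000 nM and 50000 nM.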

Compound 4, concentration for total growth inhibition: 79200 nM
The estimate for compound 4 lay 5.3-fold (0.72 log units) below the measured number; the whole stated range lies below it.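

In this assay, chloro in place of bromo on an aromatic carbon gives a 1.2-fold higher number from compound 3 to compound 4 (0.07 log units; within the scatter), so on this core the swap has no effect that can be told from the scatter. The large step seen on the first core therefore did not carry over to the second: the same change on two cores in this assay, a 16-fold lower number (1.20 log units; beyond the scatter) from compound 1 to compound 2 and a 1.2-fold higher number (0.07 log units; within the scatter) from compound 3 to compound 4, 19-fold (1.27 log units) apart, beyond the scatter of two such steps

This shows that, for these two pairs, the outcome of the swap differs with the core, but it does not show which part of the core is responsible, and two pairs give no rule for any other core. The compounds shown leave open how an amine or a carboxylic acid on this aromatic carbon would read on either core.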